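Phenol analogue of the carboxymethoxy acid in the trioxolane series

This account rests on a few compounds, and the source may have more. Where it says the series, first, only, none or still open, it means among the compounds named here.

Compound 1 `O=C(O)COc1ccc([C@H]2CC[C@]3(CC2)OOC2(O3)C3CC4CC(C3)CC2C4)cc1C(=O)O` carries a carboxymethoxy group and a carboxy group on its aromatic ring. In an ADME assay on microsomes from liver (Homo sapiens) for metabolic stability, using NADPH, with a stated time of 60 min, in the presence of a further agent that is not named here (a higher number here means faster removal of the compound, a lower number slower removal), compound 1 returns only a limit of the assay, < 7 mL.min-1.g-1. Compound 2 `O=C(O)COc1ccc([C@H]2CC[C@]3(CC2)OOC2(O3)C3CC4CC(C3)CC2C4)cc1Cl`, with chloro in place of carboxy on an aromatic carbon, also returns only a limit, < 7 mL.min-1.g-1. The step that the two limits leave unreadable from compound 1 to compound 2 is therefore not readable. Compound 3 `O=C(O)COc1ccc([C@H]2CC[C@]3(CC2)OOC2(O3)C3CC4CC2CC(C3)C4(F)F)cc1`, which carries a difluoro substitution on the adamantane part and no substituent beside the carboxymethoxy group, gives a number, 23 mL.min-1.g-1. The shared position of the two limits is noted in the limit of < 7 mL.min-1.g-1 in this assay, at which 2 of the 3 values shown sit; beyond that, the measured steps give no reading of how substituents on the aromatic ring move clearance.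

Compound 4 `O=C(O)c1cc([C@H]2CC[C@]3(CC2)OOC2(O3)C3CC4CC(C3)CC2C4)ccc1O` differs from compound 1 by hydrogen in place of carboxymethyl on an oxygen on an aromatic ring. Among the compounds with values here, no measured step bears on this change. With compound 1 itself at a limit, the size of an at least 1.1-fold higher number from compound 1 to compound 4 (0.05 log units; that floor lies within the scatter) is expected to be small, and compound 4 is estimated at 8 mL.min-1.g-1, between 3 mL.min-1.g-1 and 22 mL.min-1.g-1, with a fair chance that this assay again reports only a limit.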

Compound 4, intrinsic clearance in microsomes in the Homo sapiens assay: 108 mL.min-1.g-1
Compound 4: the middle estimate sits 14-fold (1.13 log units) below what was measured, outside the stated range (above it).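

Within the data shown here, in the Homo sapiens assay, an at least 15-fold higher number from compound 1 to compound 4 (1.18 log units; beyond the scatter), the first readable step in these notes, so the change from carboxymethoxy to hydroxy on the aromatic ring moves this read-out strongly, where the earlier step at the carboxy position could not be read. In a physicochemical assay for solubility, read by nephelometry, measured as kinetic solubility, with a stated time of 30 min, at pH 2.0 (a higher number here means a more soluble compound, a lower number a less soluble compound), compound 1 returns only a limit, > 100 ug/mL. In the physicochemical assay, compound 4 also returns only a limit, > 100 ug/mL, so the step on this read-out cannot be read: the limit of > 100 ug/mL in the physicochemical assay, at which 2 of the 2 values shown sit.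

A methyl group on this oxygen, or a longer chain ending in an amine, would show whether the step follows the free hydroxy or the loss of carboxymethyl. Going by these compounds, whether the same change gives a step of similar size with chloro in place of carboxy, as in compound 2, stays open.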